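The compounds below may be only part of what the source reports. "The series", "measured", "known", "first", "only" and "open" are said of these compounds alone.

Compound 3 `C=C1C(=O)[C@]23C[C@@]1(O)CC[C@H]2c1ccc(O)c(C)c1[C@@H]3Cn1cc(-c2ccc(OC)cc2)nn1` and compound 4 `C=C1C(=O)[C@]23C[C@@]1(O)CC[C@H]2c1ccc(O)c(C)c1[C@@H]3Cn1cc(-c2ccc(Br)cc2)nn1` share one core, compound 1 `COc1ccc(-c2cn(C[C@H]3c4c(ccc(OS(=O)(=O)c5ccc(C)cc5)c4C)[C@@H]4CC[C@@]5(C)C[C@]43CC5=O)nn2)cc1` and compound 2 `Cc1ccc(S(=O)(=O)Oc2ccc3c(c2C)[C@H](Cn2cc(-c4ccc(Br)cc4)nn2)[C@@]24CC(=O)[C@@](C)(CC[C@@H]32)C4)cc1` another, and the difference between the two cores is not broken down here. In a functional assay on SMMC-7721 cells (Homo sapiens) for cytotoxicity, read by MTT assay, with a stated time of 4 days (a lower number here means a stronger inhibitor, a higher number a weaker inhibitor), compound 3 gives 860 nM. Compound 1 reaches only the limit of this assay, namely > 20000 nM, which is not a number. Compound 2 likewise stops at the limit > 20000 nM. The change from compound 1 to compound 2 is bromo in place of methoxy on an aromatic carbon; the step that the two limits leave unreadable from compound 1 to compound 2 stays unreadable because of the limit of > 20000 nM in this assay, at which 2 of the 3 values shown sit. Going by the values given here, from compound 3 to compound 4 the same change is made, (bromo in place of methoxy on an aromatic carbon), now on a core that carries one read number, so this pair is the first in which its size could appear. The measured pair gives no guide to direction or size. The step from compound 3 to compound 4 is expected to be small, a 1.4-fold higher number from compound 3 to compound 4 (0.14 log units; within the scatter), with wide room on either side. For compound 4 the expectation in this assay is 1200 nM, between 400 nM and 4000 nM.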

Compound 4, half-maximal inhibitory concentration: 1300 nM
The estimate for compound 4 lay 1.1-fold (0.03 log units) below the measured number; the range from low to high includes it.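

In this assay, bromo in place of methoxy on the core that carries read numbers gives a 1.5-fold higher number from compound 3 to compound 4 (0.18 log units; within the scatter), so on this core the two values cannot be told apart. On the core of compound 1 and compound 2, the same change from 4-methoxyphenyl to 4-bromophenyl cannot be read, because both compounds stand at a limit of the assay, which is not a number: the limit of > 20000 nM in this assay, at which 2 of the 4 values shown sit. The change has therefore been sized on one core and in one pair only, and nothing shows whether it would behave alike on the other core.

Open, on these data alone, is whether an amine or a carboxylic acid on the same aromatic carbon, in place of methoxy or bromo, would give a number on the core of compound 3 and compound 4 that stands apart from these two. Also open is which single difference between the two cores goes with the read numbers, as the compounds shown do not break that difference down.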